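Solubility Notes: Cyano for Methoxy on Compound 3

The compounds below may be only part of what the source reports. "The series", "measured", "known", "first", "only" and "open" are said of these compounds alone.

Measured so far in a physicochemical assay for solubility; on this read-out higher numbers stand for higher solubility and lower numbers for lower solubility:
- compound 1 `CNC(=O)c1cc(C(=O)NC2CC2)cn(Cc2ccc(F)cc2)c1=O`: compound 1 gives >= 162 ug/mL, a limit of the assay
- compound 2 `CNC(=O)c1cc(C(=O)NC2CC2)cn(CC2CCCCC2)c1=O`: compound 2 gives >= 148 ug/mL, a limit of the assay
- compound 3 `CNC(=O)c1cc(C(=O)NC2CC2)cn(Cc2cccc(OC)c2)c1=O`: compound 3 gives 79 ug/mL

Among the measured compounds shown here, compound 3 holds the only real number in this assay; the other two values are limits. The step of an at least 2.0-fold lower number from compound 1 to compound 3 (0.31 log units; beyond the scatter) is beyond the scatter, while the step of an at least 1.8-fold lower number from compound 2 to compound 3 (0.27 log units; that floor lies within the scatter) has a floor that lies within it. The step that the two limits leave unreadable from compound 1 to compound 2 cannot be read because the limit of >= 148 ug/mL in this assay, at which 1 of the 3 values shown sits, and the limit of >= 162 ug/mL in this assay, at which 1 of the 3 values shown sits, cap both values.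

Compound 4 `CNC(=O)c1cc(C(=O)NC2CC2)cn(Cc2cccc(C#N)c2)c1=O` differs from compound 3 by cyano in place of methoxy on an aromatic carbon. Both measured steps into compound 3 exchange the whole ring on the saturated chain carbon bound to the aromatic nitrogen, not a substituent on an otherwise kept 3-substituted phenyl, so neither bears directly on this change. For the measured compounds named here, with no direct precedent, no step beyond the scatter is expected in this assay, and the step of a 1.0-fold higher number from compound 3 to compound 4 (0.01 log units; within the scatter) is the estimate. Compound 4 is therefore expected to give about 80 ug/mL in this assay, with a range from 40 ug/mL to 160 ug/mL.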

Compound 4, solubility: >= 148 ug/mL
Compound 4: no number, only a limit (the forecaster's own chance of this, stated with the estimate: 15%); at least 1.8-fold (0.26 log units) between middle value and limit.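

In this assay compound 4 gives >= 148 ug/mL, which is a limit of the assay and not a number. The change from 3-methoxyphenyl to 3-cyanophenyl is the first one shown that keeps the ring on the saturated chain carbon and alters only its substituent, and it gives an at least 1.8-fold higher number from compound 3 to compound 4 (0.27 log units; that floor lies within the scatter). With methoxy on this aromatic carbon, the series now has the only real number in the assay, while the two ring exchanges from compound 1 and compound 2 to compound 4 cannot be read because both ends of each step are limits: the limit of >= 148 ug/mL in this assay, at which 2 of the 4 values shown sit.

Still open, on these data alone, is how far compound 4 lies past its limit, and with that whether cyano in place of methoxy truly passes the scatter or stays within it. Also open is how other groups on the same aromatic carbon, such as an amine or a carboxylic acid, would read in this assay, since only methoxy and cyano are shown there.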